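The compounds below may be only part of what the source reports. "The series", "measured", "known", "first", "only" and "open" are said of these compounds alone.

Measured compounds:
Compound 1 `CO[C@@H]1CC=C2NN(c3c[nH]c4ccccc34)C(=O)CC[C@]2(c2ccccc2)O1` gives 1110 nM in a functional assay on A549 cells (Homo sapiens) for cytotoxicity, read by sulforhodamine B assay, with a stated time of 48 h; a lower number here means a stronger inhibitor, a higher number a weaker inhibitor.
Compound 2 `CO[C@@H]1CC=C2N(c3ccc([N+](=O)[O-])cc3)C(=O)C[C@]2(c2ccccc2)O1` gives 7150 nM in this assay.
Compound 3 `COc1cc(OC)cc(N2C(=O)C[C@]3(c4ccccc4)O[C@H](OC)CC=C23)c1` gives 4110 nM in this assay.

Compound 2 gives the highest of the three numbers. Its nearest neighbour is compound 3, and the gap between the two lies within the scatter, so nothing separates them. Among the compounds with values here, compound 1 lies furthest away, with a number that sits beyond the scatter below that of compound 2; compound 1 does not share the core of compound 2, however, so no single step connects them, and only the two values themselves can be compared.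

The unmeasured compound 4 `CO[C@@H]1CC=C2N(c3c[nH]c4ccccc34)C(=O)C[C@]2(c2ccccc2)O1` keeps the core of compound 2 and differs from it in one place: 1H-indol-3-yl in place of 4-nitrophenyl on an amide-type nitrogen in a ring. Within the data shown here, no measured pair shows this change on this core. Among the measured compounds shown here, the one measured compound that carries the same 1H-indol-3-yl group, compound 1, gives a clearly lower number, and that is the only guide here. A downward step of moderate size is therefore expected from compound 2 to compound 4, namely a 2.9-fold lower number from compound 2 to compound 4 (0.46 log units; beyond the scatter), although the different core of compound 1 makes this uncertain. Compound 4 is estimated at 2500 nM in this assay, with a range from 800 nM to 8000 nM.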

Compound 4, half-maximal inhibitory concentration: 5200 nM
Compound 4: middle estimate off by 2.1-fold (0.32 log units), on the low side, and the stated range covers the measured number.
By their numbers in this assay, from the lowest: compound 1; then compounds 3, 4 and 2 (each within the scatter of the next).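

Placing 1H-indol-3-yl in place of 4-nitrophenyl on the amide-type nitrogen in a ring gives, in this assay, a 1.4-fold lower number from compound 2 to compound 4 (0.14 log units; within the scatter), the first direct reading of a change at this position, and it leaves the two compounds inseparable. The two groups differ in their rings and in their counts of hydrogen-bond donors and acceptors, yet on this core the exchange produces no step beyond the scatter, so carrying the 1H-indol-3-yl group onto this core does not by itself give a clear change. Nothing available explains why the exchange leaves the number where it is.

The compounds shown leave open whether any other group on this nitrogen, such as an unsubstituted phenyl, a pyridine, or a chain ending in an amine or a carboxylic acid, would move the number beyond the scatter on this core. Within the data shown here, they also leave open what the core of compound 1 contributes, as no pair here changes the core while keeping the 1H-indol-3-yl group in place.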